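Replacing a piperidine amide with a small open-chain amide

A few compounds are considered here, and "the series" means these few. Any claim that something is new, unique, unknown or untested is made for them only; others in the source may bear on it.

Measured compounds:
- compound 1, `CCC1CCCN(C(=O)CN2CN(c3ccccc3)C3(CCN(C(=O)c4ccc(C5CCCCC5)cc4)CC3)C2=O)C1`: 2600 nM
- compound 2, `CS(=O)(=O)NCCNC(=O)CN1CN(c2ccccc2)C2(CCN(C(=O)c3ccc(C4CCCCC4)cc3)CC2)C1=O`: 2100 nM
- compound 3, `NC(=O)C1CCCN(C(=O)CN2CN(c3ccccc3)C3(CCN(C(=O)c4ccc(C5CCCCC5)cc4)CC3)C2=O)C1`: 3100 nM

All three were tested in an assay on HEK293 cells for displacement of a labelled ligand from NPC1-like intracellular cholesterol transporter 1 (Homo sapiens); a lower number here means a stronger inhibitor, a higher number a weaker inhibitor. Compound 3 gives the highest number of the three, but its distances to the others are small: a 1.2-fold higher number from compound 1 to compound 3 (0.08 log units; within the scatter) and a 1.5-fold higher number from compound 2 to compound 3 (0.17 log units; within the scatter). The three numbers therefore cannot be told apart, and none of them marks a stronger or weaker compound.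

Compound 4, `O=C(CN1CN(c2ccccc2)C2(CCN(C(=O)c3ccc(C4CCCCC4)cc3)CC2)C1=O)NCO`, has not yet been measured. It differs from compound 3 in one place: (hydroxymethyl)amino in place of 3-carbamoylpiperidin-1-yl on a carbonyl carbon.

For the measured compounds named here, two measured steps bear on this. The step of a 1.2-fold lower number from compound 1 to compound 2 (0.09 log units; within the scatter) swapped a piperidine ring for an open chain ending in a methanesulfonamide, and the step of a 1.5-fold higher number from compound 2 to compound 3 (0.17 log units; within the scatter) went the other way, from an open chain to a carbamoyl-bearing piperidine. Both left the number within the scatter. The change to compound 4 again exchanges a piperidine for a short open chain, here a (hydroxymethyl)amino group, so no step beyond the scatter is expected in this assay.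

The expected number for compound 4 is 2800 nM, with a range from 1200 nM to 6500 nM, which amounts to an expected step of a 1.1-fold lower number from compound 3 to compound 4 (0.04 log units; within the scatter).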

Compound 4, half-maximal inhibitory concentration: 8300 nM
Estimate against measurement, compound 4: 3.0-fold (0.47 log units) below, outside the stated range (above it).
By their numbers in this assay, from the lowest: compounds 2, 1 and 3 (each within the scatter of the next); then compound 4.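

In this assay, for the compounds shown here, this place on the carbonyl carbon had so far taken very different groups with no readable change, but (hydroxymethyl)amino is the first group to move the number beyond the scatter, with a 2.7-fold higher number from compound 3 to compound 4 (0.43 log units; beyond the scatter), a 3.2-fold higher number from compound 1 to compound 4 (0.50 log units; beyond the scatter) and a 4.0-fold higher number from compound 2 to compound 4 (0.60 log units; beyond the scatter). Giving up the piperidine ring for an open chain is therefore not enough to decide the outcome, since compound 2 also carries an open chain and stays within the scatter of the two piperidine amides, whereas compound 4 does not; the group on the open chain matters, though all three steps are only modest. No measurement shown here explains this difference.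

From the compounds shown here alone, it remains open whether the rise in the number goes with the short length of the chain or with its hydroxy end. A longer chain ending in hydroxy, such as 2-hydroxyethylamino, and a plain methylamino group would help separate these two readings, while a chain ending in a carboxylic acid or an amine would test how far this place accepts other end groups.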